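Compound 3: 2,4-dichlorophenyl on the chain carbon

The source may report more compounds than this note shows. Statements on the series, on what has been measured and on what is new or still open speak of the compounds shown alone.

- Compound 1 `O=C(NCc1ccc2cccnc2c1O)C1CCCCC1`: 910 nM
- Compound 2 `O=C(NCc1ccc2c(OCc3ccccc3)ccnc2c1O)C1CCCCC1`: 550 nM

Among the measured compounds shown here, in a functional assay on A-375 cells (Homo sapiens) for antiproliferative activity, read by trypan blue exclusion and crystal violet staining, with a stated time of 72 h (a lower number here means a stronger inhibitor, a higher number a weaker inhibitor), compound 1 gives 910 nM, within the scatter of compound 2, the only other measured compound. Compound 3 `O=C(NC(c1ccc(Cl)cc1Cl)c1ccc2cccnc2c1O)C1CCCCC1` differs from compound 1 as follows: 2,4-dichlorophenyl in place of hydrogen on a saturated chain carbon bound to an amide-type nitrogen and an aromatic carbon. For the measured compounds named here, the only measured step is a 1.7-fold lower number from compound 1 to compound 2 (0.22 log units; within the scatter). It places benzyloxy on an aromatic carbon, not on the chain carbon, so it bears only loosely on this change. A modest step toward a lower number is expected in this assay, with wide uncertainty. The expected step is a 2.3-fold lower number from compound 1 to compound 3 (0.36 log units; beyond the scatter). Compound 3 is estimated at 400 nM, with an expected range of 100 nM to 1500 nM.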

Compound 3, half-maximal inhibitory concentration: 1010 nM
Compound 3: middle estimate off by 2.5-fold (0.40 log units), on the low side; the measured number falls inside the stated range.
By their numbers in this assay, from the lowest: compounds 2, 1 and 3 (each within the scatter of the next).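

In this assay, 2,4-dichlorophenyl in place of hydrogen on the saturated chain carbon gives a 1.1-fold higher number from compound 1 to compound 3 (0.05 log units; within the scatter), so this position accepts the group without a change beyond the scatter. Compound 3 is the only compound shown with a substituent on this carbon, so this reading rests on a single group. No measured evidence bears on this result.

Going by these compounds, whether a plain phenyl, an amine or a carboxylic acid on the same carbon would give a similar number remains open. Also open, on these data alone, is how 2,4-dichlorophenyl here would combine with the benzyloxy of compound 2.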